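Replacing a hydrogen with nitro on compound 1

The source may report more compounds than this note shows. Statements on the series, on what has been measured and on what is new or still open speak of the compounds shown alone.

Within the data shown here, in a physicochemical assay for acid dissociation, compound 1 `O=S(=O)(Nc1ccccc1)c1ccccc1` gives 9.1 which is the higher of the two numbers measured so far. Compound 2 `O=S(=O)(Nc1ccccc1)c1ccc(Cl)cc1` gives 8.47 in this assay and differs by chloro in place of hydrogen on an aromatic carbon. Compound 3 `O=[N+]([O-])c1cccc(S(=O)(=O)Nc2ccccc2)c1` has not yet been measured. Among the measured compounds shown here, its single change from compound 1 is nitro in place of hydrogen on an aromatic carbon, meta to a large group (nitro in place of hydrogen on an aromatic carbon). Only the chloro swap bears on this change, and it was a modest step (a number 0.63 log units lower from compound 1 to compound 2 (beyond the scatter)). For the measured compounds named here, no nitro compound has been measured, so the size of the new step is a judgement. The direction is expected to match the chloro step, with a larger size (a number 1.50 log units lower from compound 1 to compound 3 (beyond the scatter)). For compound 3 the estimated value is 7.6 (expected range 7 to 8.2).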

Compound 3, acid dissociation constant: 7.5
Beside the measured number, compound 3's estimate is 0.10 log units above it, and the stated range covers the measured number.
By their numbers in this assay, from the lowest: compound 3; then compound 2; then compound 1.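

Placed on an aromatic carbon meta to a large group, nitro gives in this assay a number 1.60 log units lower from compound 1 to compound 3 (beyond the scatter), which shows that a single change at this place on the core of compound 1 can shift the number by a large step. The chloro swap gave a number 0.63 log units lower from compound 1 to compound 2 (beyond the scatter), so both replacements of hydrogen shown so far point the same way, with the nitro step the larger of the two. No measurement shown here accounts for the size of the nitro step.

Among these compounds, with only one group at this place, how much of the step belongs to nitro itself and how much to where it sits remains open. An amine or a carboxylic acid on the same aromatic carbon would show whether the number can also rise from here, or fall by less.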